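A few compounds are considered here, and "the series" means these few. Any claim that something is new, unique, unknown or untested is made for them only; others in the source may bear on it.

Measured compounds in a functional assay on SNU-16 cells (Homo sapiens) for antiproliferative activity, read by CCK-8 assay, with a stated time of 72 h; a higher number here means a weaker inhibitor, a lower number a stronger inhibitor:
Compound 1 `CCN1CCN(c2ccc(C(=O)Nc3n[nH]c4cc(-c5c(F)cc(F)c(OC)c5F)ccc34)cc2)CC1` gives > 1000 nM, a limit of the assay rather than a number.
Compound 2 `CCN1CCN(c2ccc(C(=O)Nc3n[nH]c4cc(-c5cccc(OC)c5F)ccc34)cc2C(F)(F)F)CC1` gives > 1000 nM, likewise a limit.
Compound 3 `CCN1CCN(c2ccc(C(=O)Nc3n[nH]c4cc(-c5cccc(OC)c5F)cc(F)c34)cc2)CC1` gives > 1000 nM, also a limit.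

Among the compounds with values here, compound 1 therefore stands at the limit of > 1000 nM in this assay, at which 3 of the 3 values shown sit, and no measured pair in the set differs in only one place, so no step size is known. Compound 4 `CCN1CCN(c2ccc(C(=O)Nc3n[nH]c4cc(-c5c(F)ccc(OC)c5F)ccc34)cc2)CC1` differs from compound 1 by hydrogen in place of fluoro on an aromatic carbon. Since the three comparators all sit at the same limit, nothing suggests that this change would bring compound 4 into the measurable range in this assay. The expected step is a step that the limit leaves unreadable from compound 1 to compound 4, with no change expected beyond the scatter. Compound 4 is estimated at 2000 nM, with a range from 500 nM to 10000 nM in this assay.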

Compound 4, half-maximal inhibitory concentration: 77.4 nM
Beside the measured number, compound 4's estimate is 26-fold (1.41 log units) above it; the whole stated range lies above it.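

In this assay, the change from 2,4,6-trifluoro-3-methoxyphenyl to 2,6-difluoro-3-methoxyphenyl gives an at least 12-fold lower number from compound 1 to compound 4 (1.11 log units; beyond the scatter), so a single fluoro group, ortho to a methoxy group and para to a large group, separates these two compounds. The value of compound 1, > 1000 nM, is a limit of the assay. Compound 4 alone leaves that limit among the compounds shown: the limit of > 1000 nM in this assay, at which 3 of the 4 values shown sit.

On these data alone, it remains open whether chloro, methyl or an amine in this place would behave like the hydrogen of compound 4 or like the fluoro of compound 1.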